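From Methoxy to Trifluoromethoxy: Estimating Compound 4

The source may hold more compounds than are shown below. What is called first, only, known or untested is meant among the compounds shown, and "the series" means these compounds.

Of the compounds shown here, three have been measured in a functional assay on PC-3 cells (Homo sapiens) for inhibition, read by MTT assay, with a stated time of 72 h; on this read-out higher numbers stand for weaker inhibition and lower numbers for stronger inhibition. Compound 1 `O=C(NNC(=O)C1CC1c1ccc(OC(F)(F)F)cc1)c1ccncc1` has a core unlike that of the others and reaches only a limit, > 100000 nM, which is a boundary of the assay rather than a number (the limit of > 100000 nM in this assay, at which 1 of the 3 values shown sits). Compound 2 `COc1ccc(C2CC2C(=O)NNc2nncc3ccccc23)cc1` gives 64000 nM in this assay, and compound 3 `O=C(NNc1nncc2ccccc12)C1CC1c1ccc(OCC(F)(F)F)cc1` gives 67000 nM. Compound 2 holds the lower of the two numbers, with compound 3 its nearest neighbour, and the step of a 1.0-fold higher number from compound 2 to compound 3 (0.02 log units; within the scatter) sits within the scatter.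

Compound 4 `O=C(NNc1nncc2ccccc12)C1CC1c1ccc(OC(F)(F)F)cc1` differs from compound 2 by trifluoromethyl in place of methyl on an oxygen on an aromatic ring. A single measured step bears on this: a 1.0-fold higher number from compound 2 to compound 3 (0.02 log units; within the scatter), where a trifluoromethyl also entered, one bond further out along the chain, and the number stayed put. For the measured compounds named here, compound 1, the one measured compound carrying trifluoromethoxy, yields only a limit and so offers no number to lean on. For compound 4 the expected step of a 1.1-fold higher number from compound 2 to compound 4 (0.04 log units; within the scatter) is therefore none beyond the scatter. Compound 4 is thus estimated at 70000 nM in this assay, with a range from 30000 nM to 160000 nM.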

Compound 4, half-maximal inhibitory concentration: 92000 nM
Compound 4: the middle estimate sits 1.3-fold (0.12 log units) below what was measured; measured number inside the range.
By their numbers in this assay, from the lowest: compounds 2, 3 and 4 (each within the scatter of the next). At a limit, above all of these: compound 1.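

In this assay, changing methoxy to trifluoromethoxy on the aromatic ring gives a 1.4-fold higher number from compound 2 to compound 4 (0.16 log units; within the scatter) and so leaves no readable change from putting trifluoromethyl in place of methyl on this oxygen. Going from 2,2,2-trifluoroethyl to trifluoromethyl on the same oxygen gives a 1.4-fold higher number from compound 3 to compound 4 (0.14 log units; within the scatter) and likewise changes nothing that can be read, so methyl, 2,2,2-trifluoroethyl and trifluoromethyl cannot be told apart at this place. The scale of this read-out also ends at a limit, which compound 1 reaches: the limit of > 100000 nM in this assay, at which 1 of the 4 values shown sits.

Going by these compounds, whether a longer chain such as butyl, or a chain ending in an amine, on this oxygen would move the number beyond the scatter stays open. Also open, on these data alone, is how trifluoromethoxy acts on the core of compound 1, whose limit offers no number for comparison.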